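The compounds below may be only part of what the source reports. "The series", "measured", "known", "first", "only" and "open" are said of these compounds alone.

Measured so far in a physicochemical assay for solubility, at pH 7.4; on this read-out higher numbers stand for higher solubility and lower numbers for lower solubility:
Compound 1 `CC(C)Nc1nc(NCc2ccco2)c2ccccc2n1` gives >= 30000 nM; this is a limit of the assay, not a number.
Compound 2 `CC(C)Nc1nc(NCc2ccco2)c2c(Cl)cccc2n1` gives <= 10000 nM; this too is a limit of the assay.
Compound 3 `Cc1cccc2nc(NC(C)C)nc(NCc3ccco3)c12` gives <= 10000 nM; again a limit of the assay.

Among the measured compounds shown here, compound 3 therefore sits at the limit of <= 10000 nM in this assay, at which 2 of the 3 values shown sit, while the only value not at that limit sits at the limit of >= 30000 nM in this assay, at which 1 of the 3 values shown sits. Compound 3 thus stands at the low end of what the series has shown so far.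

The next compound, compound 4 `COc1cccc2nc(NC(C)C)nc(NCc3ccco3)c12`, differs from compound 3 by methoxy in place of methyl on an aromatic carbon.

Of the measured steps, an at least 3.0-fold lower number from compound 1 to compound 2 (0.47 log units; beyond the scatter) and an at least 3.0-fold lower number from compound 1 to compound 3 (0.47 log units; beyond the scatter) both replace hydrogen rather than methyl, and a step that the two limits leave unreadable from compound 2 to compound 3 is the nearest analogy but gives no readable size. For the measured compounds named here, no measured step covers a methyl to methoxy exchange, so the expectation rests mainly on where compound 3 sits.

Compound 4 is expected in this assay at about 8000 nM, within 2500 nM to 25000 nM. This estimate corresponds to an expected step that the limit leaves unreadable from compound 3 to compound 4, which is within the scatter, with a fair chance that only a limit is again reported.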

Compound 4, solubility: <= 20000 nM
Compound 4 was reported as a limit; the forecaster's own chance of this, stated with the estimate: 60%; the middle value lies beyond the limit too.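

In this assay, among the compounds shown here, the report for compound 4 is a limit of the assay, not a number, and no other compound shown sits at it: the limit of <= 20000 nM in this assay, at which 1 of the 4 values shown sits. Methoxy on this aromatic carbon gives an at least 1.5-fold lower number from compound 1 to compound 4 (0.17 log units; that floor lies within the scatter) and so, unlike chloro and methyl at the same place, shows no step away from the hydrogen of compound 1 that is certain to lie beyond the scatter. The steps joining compound 4 to compound 2 and to compound 3 cannot be read, so methoxy cannot be ranked against chloro or methyl here.

Where compound 4 truly lies behind its limit remains open. Also open, on these data alone, is whether any substituent at this place, such as an amine or a carboxylic acid, would stay level with compound 1.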